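A Dichlorophenyl in Place of the Phenoxymethyl Carbonyl

The compounds below may be only part of what the source reports. "The series", "measured", "known", "first", "only" and "open" are said of these compounds alone.

Of the compounds shown here, three built on one shared core have been measured in a functional assay on cells (T-cell, Homo sapiens) for inhibition; a higher number here means a weaker inhibitor, a lower number a stronger inhibitor. Compound 1, `CCOc1nc(N)nc2ncc(-c3ccc(Cl)c(Cl)c3)nc12`, gives only a limit there, > 10000 nM. Compound 2, `COc1ccc(-c2cnc3nc(N)nc(N4CCN(C(=O)COc5ccccc5)CC4)c3n2)cc1OC`, gives 4 nM, and compound 3, `COc1ccc(-c2cnc3nc(N)nc(NC(C)C)c3n2)cc1OC`, gives 600 nM. Of the two numbers shown, compound 2 holds the lower; the nearest number is that of compound 3, and the gap between the two lies beyond the scatter of this assay. The third value sits at the limit, (the limit of > 10000 nM in this assay, at which 1 of the 3 values shown sits).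

Compound 4, `COc1ccc(-c2cnc3nc(N)nc(N4CCN(c5cc(Cl)cc(Cl)c5)CC4)c3n2)cc1OC`, remains to be measured. It differs from compound 2 in one place: 3,5-dichlorophenyl in place of (phenoxymethyl)carbonyl on an amine nitrogen in a ring. Among the measured compounds shown here, no measured step between two compounds that differ in a single place is available, so the size of this change can only be expected. The expected step is a 7.5-fold higher number from compound 2 to compound 4 (0.88 log units; beyond the scatter) in this assay , toward a higher number and beyond the scatter, yet well short of the gap that separates compound 2 from compound 3. Compound 4 is therefore estimated at 30 nM in this assay , within a range from 5 nM to 200 nM.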

Compound 4, half-maximal inhibitory concentration: 3400 nM
Beside the measured number, compound 4's estimate is 110-fold (2.05 log units) below it, outside the stated range (above it).
By their numbers in this assay, from the lowest: compound 2; then compound 3; then compound 4. At a limit, above all of these: compound 1.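

In this assay, among the compounds shown here, the swap of (phenoxymethyl)carbonyl for 3,5-dichlorophenyl on an amine nitrogen in a ring gives an 850-fold higher number from compound 2 to compound 4 (2.93 log units; beyond the scatter), the first step read at this place, since the earlier compounds offered no pair differing in one place. The step is large even though the group that enters keeps one six-membered aromatic ring of carbon only, as the group that leaves did, so such a ring on this nitrogen does not by itself hold the number of compound 2. What goes is the carbonyl and the ether oxygen, with the 2 hydrogen-bond acceptors counted for (phenoxymethyl)carbonyl, and what comes is a directly attached ring carrying two chlorine atoms, so this nitrogen is a place where the choice of group can move the number far beyond the scatter.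

The compounds shown leave open how much of the step goes with the lost carbonyl, the lost ether oxygen or the added chlorines, which a plain phenyl, a benzoyl or a 3,5-dichlorobenzoyl on the same nitrogen would begin to separate. Nothing measured here gives a reason for the size of this step.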